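Replacing an Amide Terminus with a Methoxy-Bearing Acid

The compounds below may be only part of what the source reports. "The series", "measured", "known", "first", "only" and "open" are said of these compounds alone.

Within the data shown here, compound 1 `NC(=O)CCCC/C=C(\c1ccccc1)c1cccnc1` stands at the top of the three numbers measured so far. In an assay (Equus caballus) for inhibition of Thromboxane-A synthase (Homo sapiens), using microsomes (a higher number here means a weaker inhibitor, a lower number a stronger inhibitor), compound 1 gives 400 nM. Compound 2 `O=C(O)CCCC/C=C(\c1cccnc1)c1cccc([N+](=O)[O-])c1` gives 73 nM, a lower number that lies beyond the usual scatter. Compound 3 `CC(C)(CCCC/C=C(/c1ccccc1)c1cccnc1)C(=O)O` gives 38 nM, the lowest of the three and likewise well beyond the scatter from compound 1. Both measured compounds that end in a carboxy group rather than a carbamoyl group therefore show lower numbers than compound 1, and none of the three goes against that.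

Compound 4 `COCC(CCC/C=C(\c1ccccc1)c1cccnc1)C(=O)O` has not yet been measured. Compared with compound 1 it carries 1-carboxy-2-methoxyethyl in place of carbamoylmethyl on a saturated chain carbon, three bonds along the chain from a double-bonded chain carbon. The carboxy end of compound 4 resembles the ends of compound 2 and compound 3, so the expectation is a step toward a lower number that is larger than the scatter, estimated as a 5.7-fold lower number from compound 1 to compound 4 (0.76 log units; beyond the scatter). On that basis compound 4 is expected to give about 70 nM in this assay, within a range of 25 nM to 250 nM.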

Compound 4, half-maximal inhibitory concentration: 41 nM
For compound 4 the middle estimate is 1.7-fold (0.23 log units) above the measured one, within the range that was stated.
By their numbers in this assay, from the lowest: compounds 3, 4 and 2 (each within the scatter of the next); then compound 1.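

Among these compounds, this is the first change here that can be read at a single place: 1-carboxy-2-methoxyethyl in place of carbamoylmethyl on a saturated chain carbon, three bonds along the chain from a double-bonded chain carbon, gives a 9.8-fold lower number from compound 1 to compound 4 (0.99 log units; beyond the scatter) in this assay and so lowers the number by more than the scatter. The place therefore accepts a larger group, with 7 heavy atoms in place of 4, without the number rising, but the step belongs to the carboxy group and the methoxy-bearing branch taken together. Nothing measured here explains the step.

As far as these compounds go, how much of the step comes from each of those two parts stays open. Also open, from the compounds shown here alone, is whether a hydroxy group in place of the methoxy group, or a tetrazole in place of the carboxy group, would keep the number this low.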